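Adding one methoxy group to compound 2

This account rests on a few compounds, and the source may have more. Where it says the series, first, only, none or still open, it means among the compounds named here.

Compound 1 `COc1ccc(/C=C2\CCC/C(=C\c3cccc(OC)c3OC)C2=O)cc1OC`: 14900 nM
Compound 2 `COc1cc(/C=C2\CCC/C(=C\c3cccc(OC)c3OC)C2=O)cc(OC)c1`: 13100 nM

In an ADME assay on NHDF cells (Homo sapiens) for cytotoxicity, read by MTT assay, with a stated time of 72 h (a lower number here means a stronger inhibitor, a higher number a weaker inhibitor), compound 2 gives 13100 nM, within the usual scatter of compound 1 at 14900 nM, so these two cannot be told apart. Compound 3 `COc1cccc(/C=C2\CCC/C(=C\c3cc(OC)c(OC)c(OC)c3)C2=O)c1OC` has one structural change from compound 2: methoxy in place of hydrogen on an aromatic carbon. Among the compounds with values here, no measured pair shows the effect of this change, so no shift beyond the scatter is expected, in either direction. The expected 1.1-fold lower number from compound 2 to compound 3 (0.04 log units; within the scatter) is small. For compound 3 the estimate is 12000 nM, with an expected range from 5000 nM to 28000 nM.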

Compound 3, half-maximal inhibitory concentration: 7900 nM
Compound 3: middle estimate off by 1.5-fold (0.18 log units), on the high side; the range from low to high includes it.
By their numbers in this assay, from the lowest: compounds 3, 2 and 1 (each within the scatter of the next).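

In this assay, a methoxy group in place of hydrogen, on the aromatic carbon ortho to two methoxy groups and para to a large group, gives a 1.7-fold lower number from compound 2 to compound 3 (0.22 log units; within the scatter) and a 1.9-fold lower number from compound 1 to compound 3 (0.28 log units; within the scatter). So a third methoxy group on this ring produces no shift that can be told from the scatter. Nothing available here explains these numbers.

On these data alone, whether an amine, a carboxylic acid or a longer chain such as butoxy at this position would move the number beyond the scatter remains open.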